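This account rests on a few compounds, and the source may have more. Where it says the series, first, only, none or still open, it means among the compounds named here.

Series notes. Compound 1 `CC(C)(C)c1ccc(CNCCCNS(=O)(=O)c2cc(C(F)(F)F)cc(C(F)(F)F)c2)cc1`, compound 2 `O=S(=O)(NCCNCc1ccc(-c2ccccc2)cc1)c1cc(C(F)(F)F)cc(C(F)(F)F)c1` and compound 3 `O=S(=O)(NCCCNCc1ccc(-c2ccccc2)cc1)c1cc(C(F)(F)F)cc(C(F)(F)F)c1` share a sulfonamide core and have each been run in a functional assay on DU-145 cells (Homo sapiens) for inhibition, read by MTT assay, with a stated time of 72 h; a higher number here means a weaker inhibitor of growth, a lower number a stronger inhibitor of growth. In this assay compound 1 gives 2700 nM, compound 2 gives 2500 nM and compound 3 gives 2700 nM; the three numbers sit within the scatter of one another, so no order among them is claimed. One single-point change is already measured: tert-butyl in place of phenyl on an aromatic carbon, giving no change at the digits printed from compound 3 to compound 1 (within the scatter). Compound 4 `CC(C)(C)c1ccc(CNCCNS(=O)(=O)c2cc(C(F)(F)F)cc(C(F)(F)F)c2)cc1` has not yet been measured. It stands to compound 2 as compound 1 stands to compound 3, the same change at the same place: tert-butyl in place of phenyl on an aromatic carbon. The difference between the core of compound 2 and the core of compound 3 is not broken down here. For the measured compounds named here, with the one measured instance of this change having given a flat result, the expected step is no change at the digits printed from compound 2 to compound 4 (within the scatter), resting on no change at the digits printed from compound 3 to compound 1 (within the scatter). Compound 4 is accordingly estimated at 2500 nM in this assay, with a likely span of 1300 nM to 5000 nM.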

Compound 4, concentration for 50% growth inhibition: 16000 nM
Compound 4: the middle estimate sits 6.4-fold (0.81 log units) below what was measured, outside the stated range (above it).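

In this assay, tert-butyl in place of phenyl on an aromatic carbon gives a 6.4-fold higher number from compound 2 to compound 4 (0.81 log units; beyond the scatter), whereas the same change on the other core gives no change at the digits printed from compound 3 to compound 1 (within the scatter). The result of this change therefore does not carry unaltered from one core to the other: the same change on two cores in this assay, no change at the digits printed (within the scatter) from compound 3 to compound 1 and a 6.4-fold higher number (0.81 log units; beyond the scatter) from compound 2 to compound 4, 6.4-fold (0.81 log units) apart, beyond the scatter of two such steps. This shows that, for these two pairs, a flat result on one core is no safe guide to the other, but it does not show which feature of the cores matters, and two pairs set no rule for the series.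

On these data alone, it remains open whether the phenyl to tert-butyl step would stay flat, grow or reverse on a core with a longer chain, or on one with an amide in place of the amine. Also open, as far as these compounds go, is whether a different group at the same place, such as cyclohexyl or methoxy, would follow phenyl or tert-butyl on each core.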